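Diarylether benzylamines: from 1-phenylethyl back to a benzyl

The compounds below may be only part of what the source reports. "The series", "measured", "known", "first", "only" and "open" are said of these compounds alone.

Measured so far in a functional assay on SW-620 cells (Homo sapiens) for inhibition, read by MTT assay, with a stated time of 72 h; a higher number here means a weaker inhibitor, a lower number a stronger inhibitor:
- compound 1, `COc1cc(Oc2cccc(Nc3ccccc3)c2)cc(OC)c1CNCc1ccc(F)cc1`, 6770 nM
- compound 2, `COc1cc(Oc2cccc(Nc3ccccc3)c2)cc(OC)c1CN[C@H](C)c1ccccc1`, 18700 nM

Compound 2 stands at the highest of the two numbers in this assay; its nearest neighbour is compound 1, a step of a 2.8-fold higher number from compound 1 to compound 2 (0.44 log units; beyond the scatter). Among the compounds with values here, that one step is the only comparison available, and it shows that moving from a benzyl-type group to 1-phenylethyl on the amine nitrogen raised the number modestly but beyond the scatter.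

Compound 3, `COc1cc(Oc2cccc(Nc3ccccc3)c2)cc(OC)c1CNCc1ccc(O)cc1`, is not yet measured. Its change from compound 2 is 4-hydroxybenzyl in place of 1-phenylethyl on an amine nitrogen. Within the data shown here, the single measured step bears on it in reverse: the 1-phenylethyl group is removed again and a benzyl with a different substituent returns. A step of about the same size back downward in this assay is therefore expected, giving a 2.5-fold lower number from compound 2 to compound 3 (0.40 log units; beyond the scatter). Compound 3 is estimated at 7500 nM, with a range of 3000 nM to 20000 nM; the hydroxyl in place of fluorine is uncharted here, so the range is kept wide.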

Compound 3, half-maximal inhibitory concentration: 7940 nM
Compound 3: the middle estimate sits 1.1-fold (0.02 log units) below what was measured, and the stated range covers the measured number.
By their numbers in this assay, from the lowest: compounds 1 and 3 (each within the scatter of the next); then compound 2.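

In this assay, 4-hydroxybenzyl in place of 1-phenylethyl on the amine nitrogen gives a 2.4-fold lower number from compound 2 to compound 3 (0.37 log units; beyond the scatter), so a second benzyl group now sits apart from the 1-phenylethyl group in the same direction as the first. Hydroxy in place of fluoro on the aromatic carbon gives a 1.2-fold higher number from compound 1 to compound 3 (0.07 log units; within the scatter), so this exchange on the benzyl ring leaves no readable difference in this assay. No measurement at hand gives a reason for either step.

The compounds shown do not separate the branching methyl of 1-phenylethyl from the substituent on the benzyl ring, a question that an unsubstituted benzyl on the same nitrogen would bear on. Also open, on these data alone, is whether a 4-aminobenzyl or 4-carboxybenzyl group would stay within the scatter of compound 1 and compound 3.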